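The compounds below may be only part of what the source reports. "The series", "measured", "known", "first", "only" and "open" are said of these compounds alone.

Compound 1 `O=C(NO)c1ccc(NCc2nc(-c3cc4ccccc4s3)nn2-c2ccccc2)cc1` gives 65.5% in an assay on Sf9 cells for inhibition of protein deacetylase HDAC6 (Homo sapiens), read by fluorescence, with a stated time of 40 min, tested at 100 nM; a lower number here means less inhibition, a higher number more inhibition at the concentration tested (going by the name of the read-out).
Compound 2 `Cc1ccc(-c2nc(CNc3ccc(C(=O)NO)cc3)n(-c3ccccc3)n2)s1` gives 79.7% in this assay.
Compound 3 `Cc1cccc(-c2nc(CNc3ccc(C(=O)NO)cc3)n(-c3ccccc3)n2)c1` gives 64.1% in this assay.

Compound 3 holds the lowest of the three numbers: compound 1 stands nearest it (a number 1.4 percentage points lower from compound 1 to compound 3 (within the scatter)) and compound 2 furthest (a number 15.6 percentage points lower from compound 2 to compound 3 (beyond the scatter)). Compound 4 `O=C(NO)c1ccc(NCc2nc(-c3ccccn3)nn2-c2ccccc2)cc1` differs from compound 3 by pyridin-2-yl in place of 3-methylphenyl on an aromatic carbon. The two measured steps that exchange the group on this same aromatic carbon are those from compound 1 and from compound 2 to compound 3, one within the scatter and one modest. Neither involves a pyridin-2-yl group, so they show only how far such an exchange tends to move the number. The step from compound 3 to compound 4 is expected to stay within the scatter, a number 2.1 percentage points lower from compound 3 to compound 4 (within the scatter). Compound 4 is therefore estimated at 62%, between 48% and 78%.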

Compound 4, a percentage reported as inhibition, at one concentration (the size of the read-out at that concentration, not a potency): 58.6%
Beside the measured number, compound 4's estimate is 3.4 percentage points above it; measured number inside the range.
By their numbers in this assay, from the lowest: compounds 4, 3 and 1 (each within the scatter of the next); then compound 2.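

Pyridin-2-yl puts a ring nitrogen into the group on this aromatic carbon for the first time, and in this assay this exchange stays within the scatter of two earlier groups: a number 5.5 percentage points lower from compound 3 to compound 4 (within the scatter) and a number 6.9 percentage points lower from compound 1 to compound 4 (within the scatter). Only the 5-methylthiophen-2-yl group stands apart from it, with a number 21.1 percentage points lower from compound 2 to compound 4 (beyond the scatter), so among these four compounds compound 2 alone is separated from the rest. Nothing available here explains that separation.

From the compounds shown here alone, how an amine, a carboxylic acid or a longer chain on this carbon would read remains open. So does whether pyridin-3-yl would match pyridin-2-yl.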